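Changing the group on the carbonyl of a dihydropyrimidinone core

The source may hold more compounds than are shown below. What is called first, only, known or untested is meant among the compounds shown, and "the series" means these compounds.

Measured so far:
- compound 1, `CC(=O)C1=C(C)NC(=O)NC1c1ccsc1`: 1%
- compound 2, `CCCC(=O)C1=C(C)NC(=O)NC1c1ccsc1`: 1%
- compound 3, `CCN(CC)C(=O)C1=C(C)NC(=O)NC1c1ccsc1`: 35%

All three compounds were tested in an assay on membranes from HeLa cells for displacement of a labelled ligand from adenosine receptor A3 (Homo sapiens), read by scintillation counting, with a stated time of 180 min, tested at 1 uM; on this read-out lower numbers stand for less inhibition and higher numbers for more inhibition at the one concentration tested (going by the name of the read-out). Compound 1 gives 1%, and compound 2 gives 1%, so the step of no change at the digits printed from compound 1 to compound 2 (within the scatter) is a change of ethyl in place of hydrogen on a saturated chain carbon bound to a carbonyl carbon. Compound 3 stands highest of the three, with 35%; the step of a number 34 percentage points higher from compound 1 to compound 3 (beyond the scatter) and the step of a number 34 percentage points higher from compound 2 to compound 3 (beyond the scatter) both come from placing diethylamino on the carbonyl carbon.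

Compound 4, `CCC(C)OC(=O)C1=C(C)NC(=O)NC1c1ccsc1`, has not yet been measured. It differs from compound 3 as follows: sec-butoxy in place of diethylamino on a carbonyl carbon. Only the two steps onto compound 3 bear on this change, and both were large; both ketone compounds gave low numbers. The change here removes the diethylamino that went with the higher number but keeps a non-carbon atom on the carbonyl carbon, so a step back towards the ketone compounds, though not all the way, is expected. Compound 4 is estimated to give 15%, within 0% to 40%, meaning an expected step of a number 20 percentage points lower from compound 3 to compound 4 (beyond the scatter).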

Compound 4, a percentage reported as inhibition, at one concentration (the size of the read-out at that concentration, not a potency): 7%
Compound 4: middle estimate off by 8 percentage points, on the high side; the range from low to high includes it.
By their numbers in this assay, from the lowest: compounds 1, 2 and 4 (each within the scatter of the next); then compound 3.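

In this assay, the step of a number 28 percentage points lower from compound 3 to compound 4 (beyond the scatter) shows that the higher number does not survive swapping the nitrogen of diethylamino for the oxygen of sec-butoxy, although the two groups match in heavy-atom count and neither carries a ring. Measured against the two ketone compounds, the picture is a number 6 percentage points higher from compound 2 to compound 4 (within the scatter) and a number 6 percentage points higher from compound 1 to compound 4 (within the scatter), so sec-butoxy on this carbonyl carbon cannot be told apart from propyl or methyl, and among these four compounds only diethylamino stands out. Nothing available explains why these two groups part ways.

On these data alone, whether other amines on the carbonyl carbon, such as dimethylamino or piperidine, also give a higher number remains open. So does whether a smaller group such as methoxy would match sec-butoxy.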